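From Chloro to Bromo on a Shared Core

The compounds below may be only part of what the source reports. "The series", "measured", "known", "first", "only" and "open" are said of these compounds alone.

In a functional assay on IMR-32 cells (Homo sapiens) for cytotoxicity, read by sulforhodamine B assay, with a stated time of 48 h (on this read-out higher numbers stand for weaker inhibition and lower numbers for stronger inhibition), compound 2 `O=C(c1cccnc1)c1cc(Cl)ccc1O` gives 19500 nM, and compound 1 `O=C(c1cccnc1)c1cc(Cl)cc(Cl)c1O` gives 28800 nM. These two numbers lie within the scatter of each other, so compound 2 holds no real rank yet. The next structure, compound 3 `O=C(c1cccnc1)c1cc(Br)ccc1O`, differs from compound 2 at one place: bromo in place of chloro on an aromatic carbon. In short, the rest of the structure stays the same.

Among the compounds with values here, only one measured step bears on this, and it is a different swap, hydrogen in place of chloro on an aromatic carbon: a 1.5-fold lower number from compound 1 to compound 2 (0.17 log units; within the scatter). Within the data shown here, with so small a step as the only guide, no change beyond the scatter is expected in this assay. The expected step is a 1.1-fold lower number from compound 2 to compound 3 (0.03 log units; within the scatter). Compound 3 is estimated at 18000 nM, with an expected range from 9000 nM to 36000 nM.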

Compound 3, half-maximal inhibitory concentration: 23400 nM
Compound 3: the middle estimate sits 1.3-fold (0.11 log units) below what was measured, within the range that was stated.
By their numbers in this assay, from the lowest: compounds 2, 3 and 1 (each within the scatter of the next).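

Putting bromo in place of chloro, on the carbon para to the hydroxy group, brings a 1.2-fold higher number from compound 2 to compound 3 (0.08 log units; within the scatter) in this assay and so leaves the two compounds indistinguishable on this read-out. Within the data shown here, the earlier step removed a chloro from elsewhere on the ring, whereas this one exchanges one halogen for another at a position that had not yet been varied, and at this position the exchange shows no measurable consequence. Nothing available here offers an explanation for this result.

The compounds shown carry only chloro or bromo at this position, so it remains open whether any group there can shift the number beyond the scatter. An amine, a carboxylic acid or a longer chain such as propyl would test this with a group quite unlike a halogen.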